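A second chlorine on the benzamide ring of compound 3

This account rests on a few compounds, and the source may have more. Where it says the series, first, only, none or still open, it means among the compounds named here.

Measured so far in an assay on HEK293 cells for inhibition of melanin-concentrating hormone receptor 1 (Homo sapiens), read by radioligand binding; on this read-out lower numbers stand for stronger inhibition and higher numbers for weaker inhibition:
- compound 1, `CN(C)c1nc(N[C@H]2CC[C@@H](NC(=O)c3ccc(F)c(F)c3F)CC2)nc2ccccc12`: 38 nM
- compound 2, `Cc1cccc(C(=O)N[C@H]2CC[C@@H](Nc3nc(N(C)C)c4ccccc4n3)CC2)c1`: 4.6 nM
- compound 3, `CN(C)c1nc(N[C@H]2CC[C@@H](NC(=O)c3cccc(Cl)c3)CC2)nc2ccccc12`: 4.5 nM

Compound 3 gives the lowest number of the three, though compound 2 sits within the scatter of it; compound 1 lies well above both. Compound 4, `CN(C)c1nc(N[C@H]2CC[C@@H](NC(=O)c3ccc(Cl)c(Cl)c3)CC2)nc2ccccc12`, differs from compound 3 by chloro in place of hydrogen on an aromatic carbon. Going by the values given here, no measured step adds a second substituent to that ring. The steps that come nearest are an 8.3-fold lower number from compound 1 to compound 2 (0.92 log units; beyond the scatter) and an 8.4-fold lower number from compound 1 to compound 3 (0.93 log units; beyond the scatter), both of which show that a ring with one meta substituent does clearly better than one carrying three fluorines, while a 1.0-fold lower number from compound 2 to compound 3 (0.01 log units; within the scatter) shows chloro and methyl at the same place being equivalent. Among the compounds with values here, a second chloro therefore has no close precedent here; the trifluorophenyl case hints that more halogen is not rewarded, but that ring is not the same change. Compound 4 is expected to stay near compound 3, with a 1.3-fold higher number from compound 3 to compound 4 (0.12 log units; within the scatter) as the estimated step, giving an estimate of 6 nM, between 2 nM and 20 nM.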

Compound 4, half-maximal inhibitory concentration: 5 nM
For compound 4 the middle estimate is 1.2-fold (0.08 log units) above the measured one; the range from low to high includes it.
By their numbers in this assay, from the lowest: compounds 3, 2 and 4 (each within the scatter of the next); then compound 1.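

In this assay, a chloro in place of hydrogen, ortho to a chloro group and para to a large group, leaves the number within the scatter, with a 1.1-fold higher number from compound 3 to compound 4 (0.05 log units; within the scatter). The 3,4-dichlorophenyl ring also stays within the scatter of 3-methylphenyl, with a 1.1-fold higher number from compound 2 to compound 4 (0.04 log units; within the scatter), yet remains clearly better than 2,3,4-trifluorophenyl, with a 7.6-fold lower number from compound 1 to compound 4 (0.88 log units; beyond the scatter), so carrying more than one halogen does not by itself bring the ring back to the level of compound 1. Nothing at hand explains why these rings rank as they do.

The compounds shown do not tell whether the 3-chloro group is needed once the new chloro is present, which 4-chlorophenyl would address. They also leave open whether this place would take a methoxy group, an amine or a carboxylic acid as readily as it takes chloro.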